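Moving a hydroxyl group on a topoisomerase inhibitor scaffold

A few compounds are considered here, and "the series" means these few. Any claim that something is new, unique, unknown or untested is made for them only; others in the source may bear on it.

Measured compounds:
- compound 1, `Oc1ccc(-c2cc(-c3cccnc3)nc(-c3ccccc3Cl)c2)cc1`: 0.9%
- compound 2, `Oc1cccc(-c2cc(-c3ccsc3)nc(-c3ccccc3Cl)c2)c1`: 0%

Both compounds were tested in an assay on isolated protein for inhibition of DNA topoisomerase 1 (Homo sapiens), with a stated time of 30 min, tested at 100 uM; on this read-out lower numbers stand for a weaker effect and higher numbers for a stronger effect at the one concentration tested. In this assay compound 1 gives 0.9%, and compound 2 gives 0%. The two numbers lie within the usual scatter of one another, so neither compound can be called the weaker or the stronger; both show essentially no inhibition at the tested concentration. Compound 2 is the reference point for the step that follows.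

Compound 3, `Oc1ccc(-c2cc(-c3ccsc3)nc(-c3ccccc3Cl)c2)cc1`, has not yet been measured. It keeps the shared core of compound 2, its 2-chlorophenyl group and its thiophen-3-yl group, and differs only in where the hydroxyl sits: 4-hydroxyphenyl in place of 3-hydroxyphenyl on an aromatic carbon. Among the compounds with values here, no measured pair shows what such a move does here, so there is no basis for expecting a step beyond the scatter in either direction.

Compound 3 is therefore expected to give about 1% in this assay, with a range from 0% to 8%, meaning an estimated step of a number 1 percentage points higher from compound 2 to compound 3 (within the scatter).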

Compound 3, a percentage reported as inhibition, at one concentration (the size of the read-out at that concentration, not a potency): 4.1%
For compound 3 the middle estimate is 3.1 percentage points below the measured one, within the range that was stated.
By their numbers in this assay, from the lowest: compounds 2, 1 and 3 (each within the scatter of the next).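

Within the data shown here, this is the first pair that differs in one place, and it tests the hydroxyl's location directly: in this assay, 4-hydroxyphenyl in place of 3-hydroxyphenyl on this aromatic carbon of the shared core gives a number 4.1 percentage points higher from compound 2 to compound 3 (within the scatter), so moving the hydroxyl here produces no step that can be told apart from repeat-measurement noise. A second single change, thiophen-3-yl in place of pyridin-3-yl with the 4-hydroxyphenyl group kept, gives a number 3.2 percentage points higher from compound 1 to compound 3 (within the scatter), so this swap at a different place on the core cannot be told apart from that noise either. No supporting measurement accompanies these results that could bear on how either change acts.

With all three compounds lying within the scatter of the next at a single concentration, these data cannot show whether either place on the core has any influence on inhibition of the enzyme. Going by these compounds, it remains open whether an amine or a carboxylic acid in place of the hydroxyl, or a longer chain carrying either one, would give a step beyond the scatter in this assay.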